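Swapping a Saturated Ring for an Aromatic One

The compounds below may be only part of what the source reports. "The series", "measured", "known", "first", "only" and "open" are said of these compounds alone.

Compound 1, `Cn1c(N2CCCC2)c(C#N)c2c(N)ncnc21`: 125 nM
Compound 2, `Cc1nn(C)cc1Nc1nc(N)c2c(C#N)c(N3CCC[C@H]3C)n(C)c2n1`: 2 nM

Both compounds were tested in an assay on isolated protein for binding affinity to Leucine-rich repeat serine/threonine-protein kinase 2 variant G2019S (Homo sapiens), read by TR-FRET and LanthaScreen, with a stated time of 2 h; a higher number here means a weaker inhibitor, a lower number a stronger inhibitor. Of the two numbers shown, compound 1 stands at the higher one, meaning it is the weaker inhibitor; compound 2 gives a far lower number, and that gap lies well beyond the scatter of this assay. Compound 2 differs from compound 1 in several places at once, so its result says nothing about any single change.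

Compound 3, `Cn1c(-n2cccc2)c(C#N)c2c(N)ncnc21`, is not yet measured. It differs from compound 1 in one place only: 1H-pyrrol-1-yl in place of pyrrolidin-1-yl on an aromatic carbon. Going by the values given here, no measured pair shows what this swap does. With nothing else to lean on, the expectation is a small step, a 1.6-fold higher number from compound 1 to compound 3 (0.20 log units; within the scatter), toward a slightly weaker inhibitor, close to the edge of the scatter. Compound 3 is therefore expected to give about 200 nM, in a range from 60 nM to 700 nM.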

Compound 3, inhibition constant: 1980 nM
For compound 3 the middle estimate is 9.9-fold (1.00 log units) below the measured one; the whole stated range lies below it.
By their numbers in this assay, from the lowest: compound 2; then compound 1; then compound 3.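

In this assay the change from pyrrolidin-1-yl to 1H-pyrrol-1-yl gives a 16-fold higher number from compound 1 to compound 3 (1.20 log units; beyond the scatter) and so shows that this position on the shared core is sensitive to which five-membered ring it carries. The two groups have the same counts of heavy atoms, hydrogen-bond donors and acceptors, yet the non-aromatic ring goes with the stronger inhibitor and the aromatic ring with the much weaker one. Nothing measured here explains why the aromatic ring fares so much worse. Still open, from the compounds shown here alone, is how a larger saturated ring such as piperidin-1-yl or an open-chain amine such as dimethylamino would perform at this position. Also open, going by these compounds, is whether the same swap would cost as much on compound 2, whose core carries further groups.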